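Unmasking One Ester: What to Expect for Compound 4

The source may report more compounds than this note shows. Statements on the series, on what has been measured and on what is new or still open speak of the compounds shown alone.

Compound 1, `CC(C)C(=O)OCOC(=O)C1=C(S[C@@H]2CN[C@H](C(=O)Nc3cccc(C(=O)OCOC(=O)C(C)C)c3)C2)[C@H](C)[C@@H]2[C@@H]([C@@H](C)O)C(=O)N12`, in an ADME assay for metabolic stability, read by LC-MS, with a stated time of 3 h, at pH 6.5, tested at 50 uM (a lower number here means that less of the compound is left, a higher number that more of the compound is left), reaches the limit of the assay, > 95%.
Compound 2, `C[C@@H](O)[C@H]1C(=O)N2C3=C(S[C@@H]4CN[C@@H](C4)C(=O)Nc4cccc(c4)C(=O)OCOCOC3=O)[C@H](C)[C@H]12`, in this assay also sits at the limit, > 95%.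
Compound 3, `CCOC(=O)OCOC(=O)C1=C(S[C@@H]2CN[C@H](C(=O)Nc3cccc(C(=O)OCOC(=O)OCC)c3)C2)[C@H](C)[C@@H]2[C@@H]([C@@H](C)O)C(=O)N12`, in this assay likewise reports only the limit, > 95%.

All three measured compounds share one boundary: the limit of > 95% in this assay, at which 3 of the 3 values shown sit. Compound 3 therefore stands where every other measured compound stands; no number separates it from compound 1 or compound 2, and a measurement of this kind cannot tell them apart.

Compound 4, `CCOC(=O)OCOC(=O)C1=C(S[C@@H]2CN[C@H](C(=O)Nc3cccc(C(=O)O)c3)C2)[C@H](C)[C@@H]2[C@@H]([C@@H](C)O)C(=O)N12`, has not yet been measured in this assay. It differs from compound 3 in a single place: hydrogen in place of ((ethoxycarbonyl)oxy)methyl on an oxygen next to a carbonyl group. Hydrogen in place of ((ethoxycarbonyl)oxy)methyl on an oxygen next to a carbonyl group leaves the rest of the shared core untouched.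

Within the data shown here, no pair of measured compounds shows a step of this kind, so there is no measured step to lean on, and everything shown sits at the limit. The expected step of a number at least 3 percentage points lower from compound 3 to compound 4 (that floor lies within the scatter) is none beyond the scatter, with some room for a lower reading. For compound 4 the estimated value is 92%, expected to fall between 75% and 99%.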

Compound 4, percent of the compound remaining: > 95%
Compound 4 gave a limit, no number (the forecaster's own chance of this, stated with the estimate: 55%); middle value at least 3 percentage points away from the limit.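

In this assay compound 4 gives > 95%, which is a limit of the assay and not a number. No step from compound 3 to compound 4 can be read, since both compounds report only the same boundary: the limit of > 95% in this assay, at which 4 of the 4 values shown sit.

The compounds shown leave open whether hydrogen in place of ((ethoxycarbonyl)oxy)methyl changes how much compound remains at all.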